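The source may hold more compounds than are shown below. What is called first, only, known or untested is meant among the compounds shown, and "the series" means these compounds.

Measured compounds:
- compound 1 `Cc1ccnc(NC(c2ccc3cccnc3c2O)c2c(Cl)cccc2Cl)c1` gives > 40000 nM
- compound 2 `Oc1cccc(C(Nc2ccccn2)c2ccc3cccnc3c2O)c1Cl` gives 370 nM

The two measured compounds share a core and differ in the groups hanging from its central saturated carbon. In an assay for inhibition of protein disulfide-isomerase (Homo sapiens), with a stated time of 1 h (a higher number here means a weaker inhibitor, a lower number a stronger inhibitor), compound 2 gives 370 nM. Compound 1, by contrast, does not give a number at all: its value of > 40000 nM is only a limit of the assay, and it sits at the limit of > 40000 nM in this assay, at which 1 of the 2 values shown sits. So compound 1 stands at the weak end of what has been seen, with no number of its own.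

Compound 3 `Cc1ccnc(NC(c2cccc(F)c2)c2ccc3cccnc3c2O)c1` has not been measured. It differs from compound 1 in one place: 3-fluorophenyl in place of 2,6-dichlorophenyl on a saturated chain carbon bound to an aromatic carbon and a nitrogen on an aromatic ring. Among the compounds with values here, no measured pair shows this exact change, so its size can only be guessed. Compound 2 shows that a smaller aryl group on that carbon can go with real inhibition, and because compound 1 sits at the limit of > 40000 nM in this assay, at which 1 of the 2 values shown sits, a move toward stronger inhibition is the more likely direction. The step from compound 1 to compound 3 is expected to be an at least 6.6-fold lower number from compound 1 to compound 3 (0.82 log units; beyond the scatter). Compound 3 is therefore estimated at 6000 nM, with a range from 600 nM to 40000 nM.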

Compound 3, half-maximal inhibitory concentration: 350 nM
Compound 3: middle estimate off by 17-fold (1.23 log units), on the high side; the whole stated range lies above it.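

Within the data shown here, compound 1 and compound 3 are the first pair here that differ in one place only, so the group on this saturated chain carbon can now be judged with the rest of the molecule held fixed. In this assay, 3-fluorophenyl in place of 2,6-dichlorophenyl gives an at least 110-fold lower number from compound 1 to compound 3 (2.05 log units; beyond the scatter), which shows that this single position can separate a compound with a measurable value from one without. The true size of the step remains unknown and could be larger still, because compound 1 has only a limit of the assay and no number of its own: the limit of > 40000 nM in this assay, at which 1 of the 3 values shown sits.

The change removes two chlorine atoms and adds one fluorine atom at the same time, so the compounds shown cannot tell which part of it matters, or whether the fluorine is needed at all. A plain phenyl ring, a phenyl ring carrying a single chlorine or a methoxy group, or a saturated cyclohexyl ring on this carbon would help to pull these parts apart, and none of these is among the compounds shown.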